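Aminophenyl to dichlorophenyl on the enone carbonyl

The source may hold more compounds than are shown below. What is called first, only, known or untested is meant among the compounds shown, and "the series" means these compounds.

Working notes on a small series of pyrazolyl enones sharing one core. Compound 1 `COc1ccc(-c2cc(/C=C/C(=O)c3ccc(N)cc3)[nH]n2)cc1` and compound 2 `COc1cc(-c2cc(/C=C/C(=O)c3ccc(N)cc3)[nH]n2)cc(OC)c1OC` differ only in the substitution of the aryl group attached to the core. In a functional assay on UACC-62 cells (Homo sapiens) for inhibition, read by sulforhodamine B assay, with a stated time of 48 h (a lower number here means a stronger inhibitor of growth, a higher number a weaker inhibitor of growth), compound 1 gives 1480 nM. In this assay compound 2 gives 1700 nM, the higher of the two numbers recorded, though the gap to compound 1 lies within the scatter, so the two are not separated. Within the data shown here, no step between measured compounds that differ in one place is available.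

Compound 3 `COc1cc(-c2cc(/C=C/C(=O)c3ccc(Cl)c(Cl)c3)[nH]n2)cc(OC)c1OC` is not yet measured. It is reached from compound 2 by the change 3,4-dichlorophenyl in place of 4-aminophenyl on a carbonyl carbon. Nothing measured here speaks to this change, so no step beyond the scatter is firmly expected; if anything, a slight lowering of the number is expected. Compound 3 is therefore estimated at 1300 nM in this assay, with a range from 450 nM to 4000 nM. The expected step is a 1.3-fold lower number from compound 2 to compound 3 (0.12 log units; within the scatter), likely within the scatter.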

Compound 3, concentration for 50% growth inhibition: 18800 nM
The estimate for compound 3 lay 14-fold (1.16 log units) below the measured number, and the stated range ends below it.
By their numbers in this assay, from the lowest: compounds 1 and 2 (each within the scatter of the next); then compound 3.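

The carbonyl-side aryl group proves to be a sensitive place in this assay: 3,4-dichlorophenyl in place of 4-aminophenyl gives an 11-fold higher number from compound 2 to compound 3 (1.04 log units; beyond the scatter), whereas the difference in the aryl group attached to the core left compound 1 and compound 2 within the scatter of each other. The series therefore now holds a change that separates its members, and compound 3 stands apart from the other two as the weakest inhibitor of growth. The change removes the amine, with its hydrogen-bond donor and acceptor, and brings in two chlorines, but nothing available ties the step to any particular property of either group.

The compounds shown leave open whether the step follows from losing the amine or from gaining the chlorines, as both differ together in this single pair; a plain phenyl, a 4-chlorophenyl or a 4-hydroxyphenyl on the carbonyl carbon would pull these apart. Also open, going by these compounds, is whether a step of this size recurs when the aryl group attached to the core is that of compound 1 rather than that of compound 2.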